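Sulfonamide series: the step to compound 4

This account rests on a few compounds, and the source may have more. Where it says the series, first, only, none or still open, it means among the compounds named here.

Values so far in an ADME assay (liver) for metabolic stability, with Liver microsome (Homo sapiens) as the target, read by LC-MS, using microsomes and NADPH, with a stated time of 5 min, at 37 degrees C (on this read-out higher numbers stand for fast clearance and lower numbers for slow clearance), are:
- compound 1 `CCn1c([C@@H](C)NS(=O)(=O)c2ccccc2)nc2ccc(C(F)(F)F)cc21` gives 14 mL.min-1.g-1 as a number
- compound 2 `CCn1c([C@@H](C)NS(=O)(=O)c2ccc(C#N)cc2)nc2ccc(C(F)(F)F)cc21` gives 34 mL.min-1.g-1 as a number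
- compound 3 `CCn1ncc(S(=O)(=O)N[C@H](C)c2nc3ccc(C(F)(F)F)cc3n2CC)c1C` gives > 100 mL.min-1.g-1 as a limit of the assay, not a number

Compound 3 stands at the limit of > 100 mL.min-1.g-1 in this assay, at which 1 of the 3 values shown sits, and so has a limit and no number. Compound 4 `CCn1c([C@@H](C)NS(=O)(=O)c2cnc(NC(C)=O)s2)nc2ccc(C(F)(F)F)cc21` is not yet measured. It carries 2-acetamido-1,3-thiazol-5-yl in place of 1-ethyl-5-methyl-1H-pyrazol-4-yl on the sulfonyl sulfur (2-acetamido-1,3-thiazol-5-yl in place of 1-ethyl-5-methyl-1H-pyrazol-4-yl on a sulfonyl sulfur).

Among the measured compounds shown here, three measured steps bear on this change, all at the group on the sulfonyl sulfur. Entry of the 1-ethyl-5-methyl-1H-pyrazol-4-yl gave an at least 7.1-fold higher number from compound 1 to compound 3 (0.85 log units; beyond the scatter) and also an at least 2.9-fold higher number from compound 2 to compound 3 (0.46 log units; beyond the scatter) in the same upward direction. The smaller change gave a 2.4-fold higher number from compound 1 to compound 2 (0.39 log units; beyond the scatter) on the same read-out. The step to compound 4 removes the 1-ethyl-5-methyl-1H-pyrazol-4-yl, so a lower number is expected, back toward the range of compound 1 and compound 2. For the measured compounds named here, no measured compound carries the entering group, which keeps the range wide, and a return to a limit cannot be excluded. The estimated change is an at least 3.3-fold lower number from compound 3 to compound 4 (0.52 log units; beyond the scatter) in this assay on present evidence. The estimated value for compound 4 is 30 mL.min-1.g-1, expected to fall within 10 mL.min-1.g-1 to 90 mL.min-1.g-1 when measured.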

Compound 4, intrinsic clearance in microsomes: 15 mL.min-1.g-1
For compound 4 the middle estimate is 2.0-fold (0.30 log units) above the measured one, within the range that was stated.
By their numbers in this assay, from the lowest: compounds 1 and 4 (each within the scatter of the next); then compound 2. At a limit, above all of these: compound 3.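

Compound 3 in this assay stands at a limit of the assay and not at a number: the limit of > 100 mL.min-1.g-1 in this assay, at which 1 of the 4 values shown sits.

On the sulfonyl sulfur, two groups that each hold one five-membered aromatic ring with 2 hetero atoms give clearly different read-outs (an at least 6.6-fold lower number from compound 3 to compound 4 (0.82 log units; beyond the scatter)), so in these two compounds that ring count does not by itself set the number. The 2-acetamido-1,3-thiazol-5-yl reads the same as phenyl within the scatter (a 1.1-fold higher number from compound 1 to compound 4 (0.03 log units; within the scatter)) and differs beyond the scatter from 4-cyanophenyl (a 2.3-fold lower number from compound 2 to compound 4 (0.36 log units; beyond the scatter)), which places compound 4 with compound 1 at the low end of the measured numbers.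

The limit on compound 3 leaves the true size of the first step unknown, and compound 4 alone cannot separate the share of the 1,3-thiazol ring from that of the acetamido part. Open as well is how an amine in place of the acetamido, or a methyl in place of the ethyl on the pyrazole, would read in this assay at this position on the sulfonyl sulfur.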